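A Carboxyethyl Group Replaces a Difluoro Ester on Nitrogen

A few compounds are considered here, and "the series" means these few. Any claim that something is new, unique, unknown or untested is made for them only; others in the source may bear on it.

- compound 1 `COc1cc(OC)c(/C=C/SCc2ccc(OC)c(N)c2)c(OC)c1`: 30 nM
- compound 2 `COC(=O)CNc1cc(CS(=O)(=O)/C=C/c2c(OC)cc(OC)cc2OC)ccc1OC`: 100 nM
- compound 3 `COC(=O)C(F)(F)Nc1cc(CS(=O)(=O)/C=C/c2c(OC)cc(OC)cc2OC)ccc1OC`: 250 nM

In a functional assay on K562 cells (Homo sapiens) for cytotoxicity, read by trypan blue exclusion, with a stated time of 96 h (a higher number here means a weaker inhibitor, a lower number a stronger inhibitor), compound 3 gives the highest number of the three at 250 nM. Compound 4 `COc1cc(OC)c(/C=C/S(=O)(=O)Cc2ccc(OC)c(N[C@@H](C)C(=O)O)c2)c(OC)c1` has not yet been measured. It carries 1-carboxyethyl in place of difluoro(methoxycarbonyl)methyl on a nitrogen on an aromatic ring. Among the measured compounds shown here, the only measured step at this nitrogen is modest: a 2.5-fold higher number from compound 2 to compound 3 (0.40 log units; beyond the scatter). For the measured compounds named here, compound 4 has no fluorine on this group, which suggests a partial return towards lower numbers, although no measured step covers a free acid here. The expected change is a 2.1-fold lower number from compound 3 to compound 4 (0.32 log units; beyond the scatter), a modest step to a lower number. Compound 4 is estimated at 120 nM, with an expected range of 35 nM to 400 nM.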

Compound 4, half-maximal inhibitory concentration: 15 nM
Compound 4: middle estimate off by 8.0-fold (0.90 log units), on the high side; the measured number lies below the stated range.
By their numbers in this assay, from the lowest: compounds 4 and 1 (each within the scatter of the next); then compound 2; then compound 3.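

At this nitrogen, the group can move the number far downward: in this assay, 1-carboxyethyl gives a 17-fold lower number from compound 3 to compound 4 (1.22 log units; beyond the scatter), and it also gives a 6.7-fold lower number from compound 2 to compound 4 (0.82 log units; beyond the scatter). The earlier step had shown only a rise, on going to the difluoro(methoxycarbonyl)methyl group. Nothing available accounts for the size of these steps.

From the compounds shown here alone, whether the drop follows the carboxylic acid or the added methyl stays open: a carboxymethyl group or the methyl ester of 1-carboxyethyl would separate the two. Going by these compounds, how the opposite configuration at the stereocentre would read is also open.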